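Swapping cyclopropylamino for hexylsulfanyl on the shared core

The source may report more compounds than this note shows. Statements on the series, on what has been measured and on what is new or still open speak of the compounds shown alone.

Compound 1 `Nc1nc(NC2CC2)c2ncn(/C=C3/CC3(CO)CO)c2n1` was tested in an ADME assay on MOLT-3 cells (Homo sapiens) for cytotoxicity, with a stated time of 7 days; a lower number here means that less compound is tolerated, a higher number that more compound is tolerated. In this assay compound 1 gives > 20000 nM, which is a limit of the assay rather than a number. Two close relatives share its core. Compound 2 `Nc1nc(NCc2ccccc2)c2ncn(/C=C3/CC3(CO)CO)c2n1` gives > 20000 nM in this assay, again a limit. Compound 3 `CCCCNc1nc(N)nc2c1ncn2/C=C1/CC1(CO)CO` gives > 20000 nM in this assay, also a limit. The steps a step that the two limits leave unreadable from compound 1 to compound 2, a step that the two limits leave unreadable from compound 1 to compound 3 and a step that the two limits leave unreadable from compound 2 to compound 3 show no readable size because of the limit of > 20000 nM in this assay, at which 3 of the 3 values shown sit. Compound 4 `CCCCCCSc1nc(N)nc2c1ncn2/C=C1/CC1(CO)CO` differs from compound 1 by hexylsulfanyl in place of cyclopropylamino on an aromatic carbon. The three measured steps change the same position and so bear on this change, yet they give neither size nor direction. For compound 4 the expected step of a number no higher from compound 1 to compound 4 (the limit leaves the size open) is none beyond the scatter. Compound 4 is estimated at 20000 nM, between 5000 nM and 60000 nM, and most likely reported again only as a limit.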

Compound 4, half-maximal cytotoxic concentration: > 20000 nM
Compound 4 gave a limit, no number; the forecaster's own chance of this, stated with the estimate: 75%; the middle value sits exactly at the limit.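

No new step can be read from compound 4 to compound 1, compound 2 or compound 3, because each gives only a limit, not a number: the limit of > 20000 nM in this assay, at which 4 of the 4 values shown sit. On these data alone, whether exchanging these groups changes the result in this assay at all, and in which direction, stays open.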